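The compounds below may be only part of what the source reports. "The series", "measured", "known", "first", "only" and "open" are said of these compounds alone.

Compound 2, with the structure `COc1cc2c(cc1OC)C(=O)/C(=C/c1ccc(CN3CCCC3)c(O)c1)CO2`, shows the lower of the two numbers recorded in an assay on isolated protein for inhibition of Amine oxidase [flavin-containing] A (Homo sapiens), read by fluorescence, with a stated time of 30 min, tested at 20 uM; on this read-out lower numbers stand for less inhibition and higher numbers for more inhibition at the one concentration tested (going by the name of the read-out); in this assay compound 2 gives 16.4%, while compound 1, with the structure `COc1cc2c(cc1OC)C(=O)/C(=C/c1cccc(O)c1)CO2`, gives 21.9%. Within the data shown here, the only measured step, a number 5.5 percentage points lower from compound 1 to compound 2 (within the scatter), arose from a (pyrrolidin-1-yl)methyl in place of hydrogen on an aromatic carbon and stayed within the scatter.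

Compound 3, with the structure `COc1ccccc1CN(C)Cc1ccc(/C=C2\COc3cc(OC)c(OC)cc3C2=O)cc1O`, has not yet been measured. It differs from compound 2 as follows: (2-methoxybenzyl)(methyl)amino in place of pyrrolidin-1-yl on a saturated chain carbon bound to an aromatic carbon. Among the measured compounds shown here, no measured step exchanges one amine for another, so the step from compound 1 to compound 2 bears on this change only loosely, by showing that adding an amine-bearing group at that part of the molecule did not move the number beyond the scatter. On that basis compound 3 is expected to sit near compound 2, with an expected step of a number 1.6 percentage points higher from compound 2 to compound 3 (within the scatter) and no shift beyond the scatter. Compound 3 is therefore estimated at 18%, with a range from 5% to 35%.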

Compound 3, a percentage reported as inhibition, at one concentration (the size of the read-out at that concentration, not a potency): 12.3%
Compound 3: the middle estimate sits 5.7 percentage points above what was measured, and the stated range covers the measured number.
By their numbers in this assay, from the lowest: compounds 3, 2 and 1 (each within the scatter of the next).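

In this assay, among these compounds, the exchange of pyrrolidin-1-yl for (2-methoxybenzyl)(methyl)amino on a saturated chain carbon bound to an aromatic carbon gave a number 4.1 percentage points lower from compound 2 to compound 3 (within the scatter), the first direct comparison of one amine with another at this place. Among the compounds shown here, the earlier step showed only that adding an amine-bearing group left the number within the scatter, whereas this one shows that the same holds when the amine is changed and brings in a six-membered aromatic ring of carbon only, so neither the ring nor the methoxy group on it separates compound 3 from compound 2 in this read-out. No measurement at hand offers an explanation for this result.

The compounds shown leave open whether any other group at this place, such as a morpholine, a piperazine or a carboxylic acid, would move the number beyond the scatter in either direction. Since each compound is described by its inhibition at a single concentration, they also leave open how the three would compare in potency.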